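Acyloxymethyl ester in place of isopropyl ester on the benzoate

A few compounds are considered here, and "the series" means these few. Any claim that something is new, unique, unknown or untested is made for them only; others in the source may bear on it.

Compound 1 `CC(C)OC(=O)c1cccc(NC(=O)[C@@H]2C[C@H](SC3=C(C(=O)O)N4C(=O)[C@H]([C@@H](C)O)[C@H]4[C@H]3C)CN2)c1` carries an isopropyl ester on the benzamide portion and a free carboxylic acid on the shared core. In an ADME assay on a cell-free system (plasma, Homo sapiens) for metabolic stability, read by LC-MS, with a stated time of 60 min, at 37 degrees C, tested at 50 uM (a higher number here means that more of the compound is left, a lower number that less of the compound is left), compound 1 gives "not determined" (no result reported), so it has no number to stand on in this series. The two neighbours that do have numbers are doubly esterified analogues: compound 2 `CC(C)OC(=O)C1=C(S[C@@H]2CN[C@H](C(=O)Nc3cccc(C(=O)OC(C)C)c3)C2)[C@H](C)[C@@H]2[C@@H]([C@@H](C)O)C(=O)N12` gives 16% in this assay, and compound 3 `Cc1oc(=O)oc1COC(=O)N1C[C@@H]2C[C@H]1C(=O)Nc1cccc(c1)C(=O)OC/C=C\COC(=O)C1=C(S2)[C@H](C)[C@@H]2[C@@H]([C@@H](C)O)C(=O)N12` gives 20% in this assay; these two values lie within the usual scatter of each other and show that little of either compound is left after the stated time.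

Compound 4 `CC(C)C(=O)OCOC(=O)c1cccc(NC(=O)[C@@H]2C[C@H](SC3=C(C(=O)O)N4C(=O)[C@H]([C@@H](C)O)[C@H]4[C@H]3C)CN2)c1` differs from compound 1 by ((isopropylcarbonyl)oxy)methyl in place of isopropyl on an oxygen next to a carbonyl group. With no number for compound 1 in this assay, neither size nor direction of the step from compound 1 to compound 4 can be set; only the new compound's value itself can be expected. Compound 4 is expected to leave 15% remaining in this assay, with a range from 3% to 45%.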

Compound 4, percent of the compound remaining in the plasma assay: 26%
Estimate against measurement, compound 4: 11 percentage points below; low and high end bracket the measured number.
By their numbers in the plasma assay, from the lowest: compounds 2, 3 and 4 (each within the scatter of the next).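

Among these compounds, no step from compound 1 to compound 4 can be read from these results. In a physicochemical assay for metabolic stability, read by LC-MS, in phosphate buffer, with a stated time of 3 h, at pH 7.4, tested at 50 uM (on this read-out lower numbers stand for a less stable compound and higher numbers for a more stable compound), compound 1 gives > 95%, which is a limit of the assay. In the physicochemical assay compound 4 gives > 95%, also a limit. The two results share that limit: the limit of > 95% in the physicochemical assay, at which 2 of the 2 values shown sit. The compounds shown leave open how far ((isopropylcarbonyl)oxy)methyl in place of isopropyl shifts the amount remaining in the plasma assay or the physicochemical assay.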